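Compound 2 at the assay limit, and a carbonyl step

The source may hold more compounds than are shown below. What is called first, only, known or untested is meant among the compounds shown, and "the series" means these compounds.

Compound 1 (`Cc1cccc(NNC(=O)c2ccccc2NS(=O)(=O)c2cnc(O)nc2O)c1`) and compound 2 (`O=C(NNc1ccc(F)cc1)c1ccccc1NS(=O)(=O)c1cnc(O)nc1O`) share one core and were both tested. In a functional assay on MDA-MB-231 cells (Homo sapiens) for antiproliferative activity, read by MTT assay, with a stated time of 24 h (on this read-out lower numbers stand for stronger inhibition and higher numbers for weaker inhibition), compound 1 gives > 20000 nM, which is a limit of the assay and not a number. In this assay compound 2 gives > 20000 nM, which is likewise only a limit. Compound 2 therefore has no numerical position and stands with compound 1 at the limit of > 20000 nM in this assay, at which 2 of the 2 values shown sit.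

Compound 3 (`Cc1ccc(C(=O)NNC(=O)c2ccccc2NS(=O)(=O)c2cnc(O)nc2O)cc1`) keeps the shared core and differs from compound 2 in one place: (4-methylphenyl)carbonyl in place of 4-fluorophenyl on an amine nitrogen. The group is thus (4-methylphenyl)carbonyl in place of 4-fluorophenyl on an amine nitrogen.

Going by the values given here, only one measured step bears on this, namely a step that the two limits leave unreadable from compound 1 to compound 2. It gives no size to carry forward, and it did not bring in a carbonyl. The expectation therefore rests on compound 1 and compound 2, which share (the limit of > 20000 nM in this assay, at which 2 of the 2 values shown sit). No change beyond the scatter is expected in either direction in this assay, and the estimated step is a number no higher from compound 2 to compound 3 (the limit leaves the size open). Compound 3 may well be reported only as a limit too. For compound 3 the estimate is 20000 nM, with an expected range from 7000 nM to 50000 nM.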

Compound 3, half-maximal inhibitory concentration: > 20000 nM
Compound 3: a limit, no number; the forecaster's own chance of this, stated with the estimate: 70%; the middle value sits exactly at the limit.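

In this assay compound 3 gives > 20000 nM, which is a limit of the assay and not a number. No new step can be read, neither between compound 2 and compound 3 nor between compound 1 and compound 3: the limit of > 20000 nM in this assay, at which 3 of the 3 values shown sit.

The compounds shown leave open how the groups on the amine nitrogen compare in this assay, as none of compound 1, compound 2 or compound 3 has a numerical position.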